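The source may hold more compounds than are shown below. What is called first, only, known or untested is meant among the compounds shown, and "the series" means these compounds.

Working notes on the series.

In a functional assay on HeLa cells (Homo sapiens) for inhibition, read by MTT assay (a lower number here means a stronger inhibitor, a higher number a weaker inhibitor), compound 1 `O=C(CN1CCN(c2ccccc2F)CC1)Nc1ccc(C(=O)/C=C/c2cn(Cc3ccc(Br)cc3)nn2)cc1` gives 9120 nM. Compound 2 `COc1ccccc1N1CCN(CC(=O)Nc2ccc(C(=O)/C=C/c3cn(Cc4ccc(Br)cc4)nn3)cc2)CC1` differs from compound 1 by methoxy in place of fluoro on an aromatic carbon, and in this assay compound 2 gives 26400 nM, so a 2.9-fold higher number from compound 1 to compound 2 (0.46 log units; beyond the scatter). Compound 3 `CCCCCCCCCCn1cc(/C=C/C(=O)c2ccc(NC(=O)CN3CCN(c4ccccc4F)CC3)cc2)nn1` differs from compound 1 in the core by nonyl in place of 4-bromophenyl on a saturated chain carbon bound to an aromatic nitrogen; in this assay compound 3 gives 47800 nM, which is a 5.2-fold higher number from compound 1 to compound 3 (0.72 log units; beyond the scatter).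

Compound 4 `CCCCCCCCCCn1cc(/C=C/C(=O)c2ccc(NC(=O)CN3CCN(c4ccccc4OC)CC3)cc2)nn1` is not yet measured. It differs from compound 3 by methoxy in place of fluoro on an aromatic carbon, the same change that separates compound 1 from compound 2, made at the same place. For the measured compounds named here, on the core of compound 3, a step of about a 2.3-fold higher number from compound 3 to compound 4 (0.36 log units; beyond the scatter) is expected, because a 2.9-fold higher number from compound 1 to compound 2 (0.46 log units; beyond the scatter) is the only measured instance of this change. Compound 4 is therefore estimated at 110000 nM in this assay, roughly between 40000 nM and 300000 nM.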

Compound 4, half-maximal inhibitory concentration: 50800 nM
The estimate for compound 4 lay 2.2-fold (0.34 log units) above the measured number; the measured number falls inside the stated range.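

On the core of compound 3, methoxy in place of fluoro gives a 1.1-fold higher number from compound 3 to compound 4 (0.03 log units; within the scatter), so the step seen on the core of compound 1 does not carry over at its size: the same change on two cores in this assay, a 2.9-fold higher number (0.46 log units; beyond the scatter) from compound 1 to compound 2 and a 1.1-fold higher number (0.03 log units; within the scatter) from compound 3 to compound 4, 2.7-fold (0.44 log units) apart, beyond the scatter of two such steps. With methoxy on the aromatic carbon, nonyl in place of 4-bromophenyl gives a 1.9-fold higher number from compound 2 to compound 4 (0.28 log units; within the scatter), a smaller step than with fluoro there: the same change on two cores in this assay, a 5.2-fold higher number (0.72 log units; beyond the scatter) from compound 1 to compound 3 and a 1.9-fold higher number (0.28 log units; within the scatter) from compound 2 to compound 4, 2.7-fold (0.44 log units) apart, beyond the scatter of two such steps. Both gaps come from the same four compounds in this assay, so they show that the two changes do not add up here, but not why, nor how either change would run on a further core.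

Open, on these data alone, is how a chloro or hydroxy group in place of fluoro would behave on either core. Also open, as far as these compounds go, is what a shorter alkyl chain in place of nonyl would give.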